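The source may hold more compounds than are shown below. What is called first, only, known or untested is meant among the compounds shown, and "the series" means these compounds.

Measured in a functional assay on MCF7 cells (Homo sapiens) for antiproliferative activity, read by MTT assay, with a stated time of 24 h; a higher number here means a weaker inhibitor, a lower number a stronger inhibitor:
compound 1 `CCn1c(C(=O)NCCNC(=O)OC(C)(C)C)ccc1C(CC)(CC)c1ccc(OCS(=O)(=O)c2ccccc2)c(C)c1`: > 50000 nM (a limit)
compound 2 `CCn1c(C(=O)N[C@@H](CO)CCCO)ccc1C(CC)(CC)c1ccc(OCS(=O)(=O)c2ccccc2)c(C)c1`: 29600 nM
compound 3 `CCn1c(C(=O)NCCC(=O)O)ccc1C(CC)(CC)c1ccc(OCS(=O)(=O)c2ccccc2)c(C)c1`: > 50000 nM (a limit)

Compound 3 stands at a limit of the assay, > 50000 nM, and so has no exact number. This is the limit of > 50000 nM in this assay, at which 2 of the 3 values shown sit. Compound 4 `CCn1c(C(=O)N[C@H](CCC(=O)O)C(=O)O)ccc1C(CC)(CC)c1ccc(OCS(=O)(=O)c2ccccc2)c(C)c1` differs from it by 1,3-dicarboxypropyl in place of 2-carboxyethyl on an amide-type nitrogen. In words, 1,3-dicarboxypropyl stands in place of 2-carboxyethyl on an amide-type nitrogen. Two measured steps change this same amide-type nitrogen substituent and bear on it: an at least 1.6-fold higher number from compound 2 to compound 3 (0.22 log units; that floor lies within the scatter) and an at least 1.6-fold lower number from compound 1 to compound 2 (0.22 log units; that floor lies within the scatter). Neither gives a size beyond the scatter, so no clear step is expected in this assay. The expected step is a number no higher from compound 3 to compound 4 (the limit leaves the size open). A further limit is the likeliest report. For compound 4 the estimated value is 50000 nM, with an expected range of 25000 nM to 100000 nM.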

Compound 4, half-maximal inhibitory concentration: > 50000 nM
Compound 4: a limit, no number; the forecaster's own chance of this, stated with the estimate: 70%; the middle value sits exactly at the limit.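

In this assay compound 4, with 1,3-dicarboxypropyl on the amide-type nitrogen, gives > 50000 nM, which is a limit of the assay. Enlarging the carboxy-bearing substituent thus does not bring a value off the limit, and the result adds a further substituent on this nitrogen that ends there: the limit of > 50000 nM in this assay, at which 3 of the 4 values shown sit. The one readable step is an at least 1.6-fold higher number from compound 2 to compound 4 (0.22 log units; that floor lies within the scatter), and the steps to compound 4 from compound 1 and compound 3 cannot be read.

From the compounds shown here alone, whether any substituent on this nitrogen gives a step beyond the scatter stays open. Going by these compounds, how an amine or a longer chain ending in hydroxy would read in this assay also stays open.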